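Shifting the nitrile within a small cyanophenyl series

A few compounds are considered here, and "the series" means these few. Any claim that something is new, unique, unknown or untested is made for them only; others in the source may bear on it.

In a functional assay on DU-145 cells (Homo sapiens) for antiproliferative activity, read by MTT assay, with a stated time of 72 h (a lower number here means a stronger inhibitor, a higher number a weaker inhibitor), compound 1 `COc1cc2c(Nc3ccc(C#N)cc3)ncnc2cc1OCCCN1CCCC1` gives 14400 nM, compound 2 `COc1cc2c(Nc3cccc(C#N)c3)ncnc2cc1OCCCN1CCCC1` gives 19100 nM and compound 3 `COc1cc2c(Nc3cccc(C#N)c3)ncnc2cc1OCCCN1CCN(C)CC1` gives 12100 nM. Compound 2 does not separate from either of the other two, as both of its steps lie within the scatter. Compound 4 `COc1cc2c(Nc3ccccc3C#N)ncnc2cc1OCCCN1CCCC1` has not yet been measured. It has the same atoms as compound 2, joined differently: 2-cyanophenyl in place of 3-cyanophenyl on a nitrogen on an aromatic ring. In words, 2-cyanophenyl stands in place of 3-cyanophenyl on a nitrogen on an aromatic ring.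

The closest evidence is a 1.3-fold higher number from compound 1 to compound 2 (0.12 log units; within the scatter), where 3-cyanophenyl replaces 4-cyanophenyl at that same place, and this step stays within the scatter. The other measured step, a 1.6-fold lower number from compound 2 to compound 3 (0.20 log units; within the scatter), puts 4-methylpiperazin-1-yl in place of pyrrolidin-1-yl on a saturated chain carbon. It bears on the question only indirectly and also stays within the scatter. Going by the values given here, no measurement yet covers 2-cyanophenyl. With a 1.3-fold higher number from compound 1 to compound 2 (0.12 log units; within the scatter) as the nearest guide, no step beyond the scatter is expected in this assay, and no direction can be favoured. The estimate amounts to an expected 1.1-fold lower number from compound 2 to compound 4 (0.05 log units; within the scatter). Compound 4 is expected at 17000 nM, within an estimated range from 9000 nM to 32000 nM.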

Compound 4, half-maximal inhibitory concentration: 18700 nM
Compound 4: middle estimate off by 1.1-fold (0.04 log units), on the low side, and the stated range covers the measured number.
By their numbers in this assay, from the lowest: compounds 3, 1, 4 and 2 (each within the scatter of the next).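

With compound 4, all three cyanophenyl groups on the nitrogen can be compared in this assay on the same pyrrolidin-1-yl side chain. Neither new step separates compound 4 from its neighbours: the change to 2-cyanophenyl gives a 1.0-fold lower number from compound 2 to compound 4 (0.01 log units; within the scatter) and, taken from the other isomer, a 1.3-fold higher number from compound 1 to compound 4 (0.11 log units; within the scatter) so both lie within the scatter. The earlier compounds shown here showed this only for 3-cyanophenyl and 4-cyanophenyl; compounds 1, 2 and 4 now show that none of the three nitrile placements can be ranked above another in this assay. No other measurement given here bears on this result or accounts for it.

On these data alone, it remains open whether 2-cyanophenyl or 4-cyanophenyl would behave the same alongside the 4-methylpiperazin-1-yl group, which appears here only in compound 3, paired with 3-cyanophenyl. Also open, as far as these compounds go, is whether this position would respond to a different group altogether, such as a carboxylic acid, a primary amide or a chlorine atom in place of the nitrile, or to a plain phenyl ring with no nitrile at all.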